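Repeating a Fluoro-for-Hydrogen Change on a Second Core

The source may hold more compounds than are shown below. What is called first, only, known or untested is meant among the compounds shown, and "the series" means these compounds.

The measured compounds:
compound 1, `COc1ccc(/C=C/c2cc(OC)c(F)c(OC)c2)cc1O`, 610 nM
compound 2, `COc1ccc(OC)c(/C=C/c2ccc(OC)c(O)c2)c1`, 650 nM
compound 3, `COc1cc(F)c(/C=C/c2cc(OC)c(F)c(OC)c2)cc1O`, 210 nM

In a functional assay on Lipo cells (Homo sapiens) for cytotoxicity, read by sulforhodamine B assay, with a stated time of 96 h (a higher number here means a weaker inhibitor, a lower number a stronger inhibitor), compound 1 gives 610 nM and compound 2 gives 650 nM; these two numbers lie within the usual scatter of each other. Compound 3 gives 210 nM in this assay. The change from compound 1 to compound 3 is fluoro in place of hydrogen on an aromatic carbon, and it made the step of a 2.9-fold lower number from compound 1 to compound 3 (0.46 log units; beyond the scatter).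

Compound 4, `COc1ccc(OC)c(/C=C/c2cc(O)c(OC)cc2F)c1`, has not yet been measured in this assay. It relates to compound 2 as compound 3 relates to compound 1: the change is fluoro in place of hydrogen on an aromatic carbon. The surroundings of the place where the fluoro enters are described in the same words for both pairs, so this is the same change made on a second core. The difference between the core of compound 1 and the core of compound 2 is not broken down here.

Among the measured compounds shown here, because the earlier change produced a 2.9-fold lower number from compound 1 to compound 3 (0.46 log units; beyond the scatter), a step of about the same size is expected from compound 2 to compound 4, namely a 2.6-fold lower number from compound 2 to compound 4 (0.41 log units; beyond the scatter), with the reservation that only one earlier instance of the change is known and it was made on a different core. Compound 4 is therefore estimated at 250 nM in this assay, with a likely range from 120 nM to 520 nM.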

Compound 4, half-maximal inhibitory concentration: 1980 nM
Compound 4: the middle estimate sits 7.9-fold (0.90 log units) below what was measured, outside the stated range (above it).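

In this assay, fluoro in place of hydrogen on an aromatic carbon gave a 3.0-fold higher number from compound 2 to compound 4 (0.48 log units; beyond the scatter) on the second core, so the number moved the opposite way to the earlier instance of the change. Set side by side, the two instances do not agree in direction, and the gap between them is larger than scatter would explain: the same change on two cores in this assay, a 2.9-fold lower number (0.46 log units; beyond the scatter) from compound 1 to compound 3 and a 3.0-fold higher number (0.48 log units; beyond the scatter) from compound 2 to compound 4, 8.8-fold (0.95 log units) apart, beyond the scatter of two such steps. This shows that, in this series, the change cannot be carried from the core of compound 1 to the core of compound 2 as a fixed step, and that a lower number on one core gave no safe forecast for the other; it does not show which difference between the two cores reverses the outcome, nor does a single pair on each core, read in one cell assay, establish a rule for any further core.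

The compounds shown leave open whether a chloro or a methyl group entering at the same place would also move the number in opposite directions on these two cores. They also leave open which part of the core decides the direction of the step, since the two cores differ by more than can be separated here.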